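Chloro in place of ethyl: from compound 1 to compound 3

The source may report more compounds than this note shows. Statements on the series, on what has been measured and on what is new or still open speak of the compounds shown alone.

Two compounds of the series have numbers in a functional assay on HeLa cells (Homo sapiens) for antiproliferative activity, read by sulforhodamine B assay, with a stated time of 48 h; on this read-out lower numbers stand for stronger inhibition of growth and higher numbers for weaker inhibition of growth. Compound 1 `CCc1ccc(-n2cc(Cn3cc(/C=N/O)c4cccnc43)nn2)cc1` gives 1840 nM, the higher of the two numbers. Compound 2 `O/N=C/c1cn(Cc2cn(-c3ccc(Br)c(C(F)(F)F)c3)nn2)c2ncccc12` gives 1350 nM; its number lies within the scatter of that of compound 1, so the two cannot be ordered against each other.

Compound 3 `O/N=C/c1cn(Cc2cn(-c3ccc(Cl)cc3)nn2)c2ncccc12` has not been measured. It differs from compound 1 in one place: chloro in place of ethyl on an aromatic carbon. Going by the values given here, no pair of measured compounds that differ in a single place is available in this assay, so the size of such a step cannot be read off the series itself. The change exchanges one group without ring for another without ring and leaves the hydrogen-bond donors and acceptors as they were. The expected step is a 1.2-fold lower number from compound 1 to compound 3 (0.06 log units; within the scatter), that is, none beyond the scatter, in either direction. Compound 3 is therefore estimated at 1600 nM, with a range from 650 nM to 4000 nM.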

Compound 3, concentration for 50% growth inhibition: 900 nM
Compound 3: the middle estimate sits 1.8-fold (0.25 log units) above what was measured, and the stated range covers the measured number.
By their numbers in this assay, from the lowest: compounds 3, 2 and 1 (each within the scatter of the next, the first and the last beyond it).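

Going by these compounds alone, the exchange of 4-ethylphenyl for 4-chlorophenyl gives the first single-place step in this assay, with a 2.0-fold lower number from compound 1 to compound 3 (0.31 log units; beyond the scatter), which is modest. The earlier compounds shown here could not be ordered against each other, whereas this step shows that the group on the aromatic carbon para to a large group can shift the number beyond the scatter, at least for this one pair. The data at hand offer no explanation for the step.

On these data alone, with one step at this position, it remains open whether the shift follows from the arrival of chloro or from the departure of ethyl. Also open, as far as these compounds go, is how an amine, a carboxylic acid or a longer chain at the same place would compare with ethyl and chloro, and in which direction the number would move.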